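From sec-butyl to 3-hydroxypropyl on the ring nitrogen

The source may hold more compounds than are shown below. What is called first, only, known or untested is meant among the compounds shown, and "the series" means these compounds.

Compound 1 `CCn1cnc2ncnc(N)c21` carries an ethyl on the ring nitrogen of the shared core. In a functional assay on CHO cells for antagonist activity at adenosine receptor A2b (Homo sapiens) (a higher number here means a weaker inhibitor, a lower number a stronger inhibitor), compound 1 reaches only the limit > 30000 nM. Compound 2 `CCCn1cnc2ncnc(N)c21` in this assay likewise gives only the limit > 30000 nM. Compound 3 `CCC(C)n1cnc2ncnc(N)c21` in this assay also stops at the limit > 30000 nM. The steps a step that the two limits leave unreadable from compound 1 to compound 2, a step that the two limits leave unreadable from compound 1 to compound 3 and a step that the two limits leave unreadable from compound 2 to compound 3 therefore cannot be read, because all three values sit at the limit of > 30000 nM in this assay, at which 3 of the 3 values shown sit. Compound 4 `Nc1ncnc2ncn(CCCO)c12` differs from compound 3 by 3-hydroxypropyl in place of sec-butyl on an aromatic nitrogen. Among the compounds with values here, no measured step bears on this change, and no measured compound has escaped the limit, so the expected step of a number no higher from compound 3 to compound 4 (the limit leaves the size open) is essentially none beyond the scatter. Compound 4 is thus expected to give about 30000 nM in this assay, within 8000 nM to 100000 nM, most likely again only as a limit.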

Compound 4, inhibition constant: > 30000 nM
Compound 4: no number, only a limit; the forecaster's own chance of this, stated with the estimate: 85%; the middle value lies on the limit itself.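

In this assay compound 4 gives only the limit > 30000 nM, so its steps from compound 1, compound 2 and compound 3 cannot be read: the limit of > 30000 nM in this assay, at which 4 of the 4 values shown sit.

The compounds shown leave open how strongly any of them inhibits, and whether the group on the ring nitrogen matters at all.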